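The compounds below may be only part of what the source reports. "The series", "measured", "known", "first", "only" and "open" are said of these compounds alone.

Within the data shown here, compound 2 `C=C1C(=O)O[C@H](C)[C@@H]1c1ccc(Br)cc1` stands at the top of the three numbers measured so far: in a functional assay on NALM-6 cells (Homo sapiens) for cytotoxicity, read by MTT assay, with a stated time of 48 h (a lower number here means a stronger inhibitor, a higher number a weaker inhibitor), compound 2 gives 4250 nM. Its nearest neighbour is compound 1 `C=C1C(=O)O[C@H](C)[C@@H]1c1ccc([N+](=O)[O-])cc1`, which carries nitro in place of bromo on the aromatic carbon; in this assay compound 1 gives 3770 nM, and the step of a 1.1-fold higher number from compound 1 to compound 2 (0.05 log units; within the scatter) lies within the scatter. Compound 3 `C=C1C(=O)O[C@@H](C)[C@@H]1c1ccc(Br)cc1` is further away: in this assay compound 3 gives 1100 nM. The step of a 3.9-fold lower number from compound 2 to compound 3 (0.59 log units; beyond the scatter) is the only one beyond the scatter, and it rests solely on (the fact that compounds 2 and 3 differ only in the configuration as drawn), the aromatic substituent being unchanged.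

Compound 4 `C=C1C(=O)O[C@H](C)[C@@H]1c1ccc(OC)cc1` is not yet measured. It differs from compound 2 by methoxy in place of bromo on an aromatic carbon. The configuration of compound 4 is drawn as in compound 2, so the stereochemical step from compound 2 to compound 3 does not bear on this change. Among the measured compounds shown here, the one step that does, the exchange of nitro for bromo from compound 1 to compound 2, was within the scatter. The expectation for compound 4 is therefore a step of a 1.1-fold lower number from compound 2 to compound 4 (0.03 log units; within the scatter) that stays within the scatter. Compound 4 is estimated at 4000 nM, with a range from 1500 nM to 11000 nM.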

Compound 4, half-maximal inhibitory concentration: 5590 nM
Estimate against measurement, compound 4: 1.4-fold (0.15 log units) below; the measured number falls inside the stated range.
By their numbers in this assay, from the lowest: compound 3; then compounds 1, 2 and 4 (each within the scatter of the next).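

With methoxy, a third substituent on the aromatic carbon para to a group of 8 heavy atoms now stands in this assay, and it does not separate from the other two: a 1.3-fold higher number from compound 2 to compound 4 (0.12 log units; within the scatter), and a 1.5-fold higher number from compound 1 to compound 4 (0.17 log units; within the scatter). Replacing bromo, with 1 heavy atom and 0 hydrogen-bond acceptors, by methoxy, with 2 heavy atoms and 1 hydrogen-bond acceptor, therefore leaves the number within the scatter, so these changes in atom count and acceptor count register no measurable difference in this small set. Among compounds 1, 2 and 4, which are drawn with the same configuration, no exchange at this position has moved the number beyond the scatter, and the one step that does exceed it remains the change in configuration, a 3.9-fold lower number from compound 2 to compound 3 (0.59 log units; beyond the scatter); nothing given here bears on why the three substituents read alike.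

Whether an amine, a carboxylic acid or a longer chain on the same aromatic carbon would stay within the scatter of these compounds remains open. On these data alone, it is also open whether the methoxy and nitro compounds would respond to the change in configuration as the bromo pair does.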